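A few compounds are considered here, and "the series" means these few. Any claim that something is new, unique, unknown or untested is made for them only; others in the source may bear on it.

Compound 2 `NC(=O)COc1ccc2c(c1)S(=O)(=O)C=C(c1c(O)c3cc(F)ccc3n(Cc3ccc(F)cc3)c1=O)N2` carries a carbamoylmethoxy group on the shared core. In an ADME assay on 2209-23 cells (Homo sapiens) for cytotoxicity, read by WST assay (a lower number here means that less compound is tolerated, a higher number that more compound is tolerated), compound 2 gives > 50000 nM, which is a limit of the assay rather than a number. Its nearest neighbour, compound 1 `N#Cc1ccc2c(c1)S(=O)(=O)C=C(c1c(O)c3cc(F)ccc3n(Cc3ccc(F)cc3)c1=O)N2`, bears a cyano group in its place. In this assay compound 1 gives > 50000 nM, again a limit of the assay. The step that the two limits leave unreadable from compound 1 to compound 2 is therefore unreadable, because the limit of > 50000 nM in this assay, at which 2 of the 2 values shown sit, holds both values. Compound 3 `CNC(=O)COc1ccc2c(c1)S(=O)(=O)C=C(c1c(O)c3cc(F)ccc3n(Cc3ccc(F)cc3)c1=O)N2` is the next member: methyl in place of hydrogen on an amide-type nitrogen. Among the compounds with values here, no measured step speaks to an alteration on an amide-type nitrogen, and the single recorded step, from cyano to carbamoylmethoxy, sits between two limits. Compound 3 is therefore expected to remain at the limit as well, the estimated step that the limit leaves unreadable from compound 2 to compound 3 meaning no change beyond the scatter. The estimate for compound 3 is 60000 nM, between 25000 nM and 150000 nM.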

Compound 3, half-maximal cytotoxic concentration: > 50000 nM
Compound 3 gave a limit, no number (the forecaster's own chance of this, stated with the estimate: 85%); the middle value does not contradict the limit.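

No step can be read among compound 1, compound 2 and compound 3 in this assay, because all three stop at the same limit of the assay: the limit of > 50000 nM in this assay, at which 3 of the 3 values shown sit. The compounds shown leave open whether methyl on the amide-type nitrogen, or either replacement of cyano, changes the tolerated concentration at all.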